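The source may hold more compounds than are shown below. What is called first, only, known or untested is meant among the compounds shown, and "the series" means these compounds.

In a functional assay on K562 cells (Homo sapiens) for antiproliferative activity, read by MTT assay (a higher number here means a weaker inhibitor, a lower number a stronger inhibitor), compound 1 (`O=C(CCCCCNC(=S)N/N=C(\c1ccccc1)c1ccccc1F)NO`) gives 4630 nM and compound 2 (`COc1cccc(/C(C)=N/NC(=S)NCCCCCC(=O)NO)c1`) gives 1910 nM as the lower of the two numbers, a gap beyond the scatter. Compound 3 (`C/C(=N\NC(=S)NCCCCCC(=O)NO)c1cccc(C)c1`) has not yet been measured. It differs from compound 2 by a single change (methyl in place of methoxy on an aromatic carbon), with methyl in place of methoxy on an aromatic carbon. Going by the values given here, no measured pair of compounds shows this change, so only a small step, within the scatter and of no clear direction, is expected. The estimated step (a 1.1-fold higher number from compound 2 to compound 3 (0.04 log units; within the scatter)) stays small. For compound 3 the expected value is 2100 nM (estimated range 900 nM to 4800 nM).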

Compound 3, half-maximal inhibitory concentration: 3840 nM
Beside the measured number, compound 3's estimate is 1.8-fold (0.26 log units) below it; low and high end bracket the measured number.
By their numbers in this assay, from the lowest: compounds 2, 3 and 1 (each within the scatter of the next, the first and the last beyond it).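

Going by these compounds alone, with 3-methoxyphenyl replaced by 3-methylphenyl, this assay records a 2.0-fold higher number from compound 2 to compound 3 (0.30 log units; within the scatter) as the first reading of methyl in place of methoxy on this aromatic carbon. The step stays within the scatter, so the two groups cannot be told apart at this place in this read-out. No information is available to explain the step. Still open, from the compounds shown here alone, is whether a chlorine, an amine or a carboxylic acid on the same carbon would move the number beyond the scatter from compound 2.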